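Chlorophenyl change from compound 2 to compound 3

The source may hold more compounds than are shown below. What is called first, only, known or untested is meant among the compounds shown, and "the series" means these compounds.

In an ADME assay on L929 cells (Mus musculus) for cytotoxicity, read by resazurin assay, with a stated time of 96 h (a lower number here means that less compound is tolerated, a higher number that more compound is tolerated), compound 1 `COc1cccc(OC/C(=N\NC(N)=S)c2ccc(Br)cc2)c1` stands at 50700 nM and compound 2 `NC(=S)N/N=C(\COc1ccccc1Cl)c1ccc(Br)cc1` stands at 25100 nM as the lower of the two numbers, with a gap between them that lies beyond the scatter. Compound 3 `NC(=S)N/N=C(\COc1cccc(Cl)c1)c1ccc(Br)cc1` comes next, and the change 3-chlorophenyl in place of 2-chlorophenyl on an oxygen on a saturated carbon puts 3-chlorophenyl in place of 2-chlorophenyl on an oxygen on a saturated carbon. Among the measured compounds shown here, no two measured compounds differ in one place only, so the series offers no direct precedent for this change. With only compound 2 at 25100 nM and compound 1 at 50700 nM as anchors, a small upward shift in this assay is expected. The estimated 1.3-fold higher number from compound 2 to compound 3 (0.12 log units; within the scatter) stays within the scatter rather than beyond it. For compound 3 the expected value is 33000 nM (estimated range 15000 nM to 75000 nM).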

Compound 3, half-maximal cytotoxic concentration: < 50200 nM
Compound 3 was reported as a limit; the forecaster's own chance of this, stated with the estimate: 5%; the middle value does not contradict the limit.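

In this assay compound 3 is reported only as a limit, < 50200 nM, and not as a number. Compound 3 gives the series its first pairs that differ in one place, 3-chlorophenyl in place of 2-chlorophenyl and chloro in place of methoxy on an aromatic carbon, but neither step can be read in size. Chloro in place of methoxy on an aromatic carbon gives a number no higher from compound 1 to compound 3 (the limit leaves the size open) and no more. The group on the oxygen on a saturated carbon has thus been changed without yielding a measured effect, and the series now holds a value that cannot be ranked: the limit of < 50200 nM in this assay, at which 1 of the 3 values shown sits.

Going by these compounds, whether 3-chlorophenyl and 2-chlorophenyl differ at all in this assay remains open. Also open, on these data alone, is what a longer chain or a group carrying an amine or a carboxylic acid would give on the same oxygen.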